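The source may hold more compounds than are shown below. What is called first, only, known or untested is meant among the compounds shown, and "the series" means these compounds.

In a functional assay on KB cells (Homo sapiens) for cytotoxicity (on this read-out lower numbers stand for an effect already at smaller amounts and higher numbers for an effect only at larger amounts of compound), three compounds sharing one core have been measured. Compound 1 `COC1=C(C)C(=O)/C(=C(O)/C=C/c2ccc(F)cc2)C(=O)C1(C)C` gives 2.7 ug/mL, compound 2 `COC1=C(C)C(=O)/C(=C(O)/C=C/c2ccc(C)cc2)C(=O)C1(C)C` gives 1.9 ug/mL, and compound 3 `COC1=C(C)C(=O)/C(=C(O)/C=C/c2ccccc2C)C(=O)C1(C)C` gives 1.6 ug/mL. Compound 3 therefore stands within the scatter of both other compounds: its nearest comparison is a 1.2-fold lower number from compound 2 to compound 3 (0.07 log units; within the scatter), and its furthest is a 1.7-fold lower number from compound 1 to compound 3 (0.23 log units; within the scatter).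

The next compound is compound 4 `COC1=C(C)C(=O)/C(=C(O)/C=C/c2cccs2)C(=O)C1(C)C`. Its structural change from compound 3 is thiophen-2-yl in place of 2-methylphenyl on a double-bonded chain carbon bound to a double-bonded chain carbon.

Going by the values given here, two measured steps bear directly on this place, a 1.7-fold lower number from compound 1 to compound 3 (0.23 log units; within the scatter) and a 1.2-fold lower number from compound 2 to compound 3 (0.07 log units; within the scatter), and both replace one substituted phenyl group with another. A third step, a 1.4-fold lower number from compound 1 to compound 2 (0.15 log units; within the scatter), also stays within the scatter. Among the compounds with values here, none of the three measured compounds carries a five-membered aromatic ring or a sulfur atom, so the data offer no direct precedent for the incoming group. With every measured step this small, no step beyond the scatter is expected in this assay, and no direction can be favoured with confidence. The estimate corresponds to an expected 1.3-fold higher number from compound 3 to compound 4 (0.10 log units; within the scatter). Compound 4 is estimated at 2 ug/mL, with an expected range from 0.9 ug/mL to 4.5 ug/mL.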

Compound 4, concentration for half-maximal effect: 3.4 ug/mL
Beside the measured number, compound 4's estimate is 1.7-fold (0.23 log units) below it; the range from low to high includes it.
By their numbers in this assay, from the lowest: compounds 3, 2, 1 and 4 (each within the scatter of the next, the first and the last beyond it).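

In this assay, the exchange on this double-bonded chain carbon gives the first step among these compounds that lies beyond the scatter (a 2.1-fold higher number from compound 3 to compound 4 (0.33 log units; beyond the scatter)), which shows that the group at this place can shift the number, though only modestly. This holds only against 2-methylphenyl: the same incoming thiophen-2-yl stays within the scatter against 4-methylphenyl (a 1.8-fold higher number from compound 2 to compound 4 (0.25 log units; within the scatter)) and against 4-fluorophenyl (a 1.3-fold higher number from compound 1 to compound 4 (0.10 log units; within the scatter)), so the five-membered sulfur-containing ring does not stand apart from the substituted phenyl groups as a whole. Nothing measured here accounts for the step.

Still open, on these data alone, is how an unsubstituted phenyl group would compare at this place, which would give the substituted phenyl groups and thiophen-2-yl a common reference. As far as these compounds go, it is also open whether other five-membered or nitrogen-containing aromatic rings, such as furan-2-yl or pyridin-3-yl, or an amine or a carboxylic acid on the aromatic ring, would move the number further in either direction.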